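A few compounds are considered here, and "the series" means these few. Any claim that something is new, unique, unknown or untested is made for them only; others in the source may bear on it.

Compound 2, with the structure `O=[N+]([O-])c1ccc(NN=C(c2ccccc2)c2ccccc2)c([N+](=O)[O-])c1`, was tested in a functional assay on cells (Melanoma tumor cell line, Homo sapiens) for cytotoxicity; on this read-out higher numbers stand for weaker inhibition and lower numbers for stronger inhibition. For compound 2 this assay reported no number but only a limit, > 10 ug/mL. A second compound from the same series, compound 1, with the structure `O=[N+]([O-])c1ccc(NN=C(c2ccccc2O)c2ccccc2O)c([N+](=O)[O-])c1`, carries two hydroxy groups on the shared core. For compound 1 this assay likewise reported only a limit, > 5 ug/mL. So both values shown are limits, the limit of > 10 ug/mL in this assay, at which 1 of the 2 values shown sits, and (the limit of > 5 ug/mL in this assay, at which 1 of the 2 values shown sits), and neither compound gave a measurable inhibition within the concentrations tried; compound 2 therefore stands at a limit, not at a number, and nothing in the two values ranks one compound against the other.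

Compound 3, with the structure `O=[N+]([O-])c1ccc(N/N=C(\c2ccccc2)c2ccc(O)cc2)c([N+](=O)[O-])c1`, differs from compound 2 by a single change: hydroxy in place of hydrogen on an aromatic carbon. For the measured compounds named here, no measured step of this kind exists within the data, so the expectation rests on the two limits alone. Given that compound 2 sat at the limit > 10 ug/mL and that the hydroxy change is small, the step from compound 2 to compound 3 is expected to be a step that the limit leaves unreadable from compound 2 to compound 3, that is, none beyond the scatter. Compound 3 is accordingly expected to give about 12 ug/mL in this assay, within a range from 4 ug/mL to 40 ug/mL.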

Compound 3, half-maximal inhibitory concentration: > 10 ug/mL
Compound 3: only a limit was reported; the forecaster's own chance of this, stated with the estimate: 60%; the middle value does not contradict the limit.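

In this assay compound 3 gave only a limit, > 10 ug/mL, and no number. For the compounds shown here, compound 2 also stands at a limit, so no step between compound 2 and compound 3 can be read. The compounds shown leave open whether hydroxy in place of hydrogen changes the result in this assay at all, and how strongly any of them inhibits.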